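The source may hold more compounds than are shown below. What is called first, only, known or untested is meant among the compounds shown, and "the series" means these compounds.

Measured compounds in an assay on HEK293-A cells for agonist activity at putative P2Y purinoceptor 10 (Mus musculus), with a stated time of 1.5 h; on this read-out lower numbers stand for smaller maximal responses and higher numbers for larger maximal responses:
compound 1 `N[C@@H](COP(=O)(O)O[C@@H]1CCCO[C@@H]1COC(=O)CCc1ccccc1OCc1cccc(Oc2ccc(Cl)cc2)c1)C(=O)O`: "not active" (no number reported)
compound 2 `CCCCCCCCCCCOc1ccccc1CCC(=O)OC[C@H]1OCCC[C@H]1OP(=O)(O)OC[C@H](N)C(=O)O`: 10.6%
compound 3 `CCCCCCCC/C=C\CCCCCCCC(=O)O[C@H]1C=CCO[C@@H]1COP(=O)(O)OC[C@H](N)C(=O)O`: "not active" (no number reported)

Among the compounds with values here, compound 2 stands as the only compound with a reported number in this assay; compound 1 and compound 3 each gave no number. Compound 4 `CCCCCCCCCCCOc1ccccc1CCC(=O)OC[C@H]1OCCC[C@@H]1OP(=O)(O)OC[C@H](N)C(=O)O` differs from compound 2 in one place: the two compounds have the same atoms and bonds; at least one stereo element is drawn with a configuration in one of them and without one in the other: 1 of 4 stereo elements differ; a stereocentre at a saturated ring carbon is drawn R in compound 2 and S in compound 4. Within the data shown here, no pair of measured compounds shows the size of such a step, so the direction of a stereochemical inversion cannot be read from the data, and a shift no larger than the usual scatter is expected. Compound 4 is therefore estimated to reach 9% in this assay, within a range of 0% to 25%, meaning an expected step of a number 1.6 percentage points lower from compound 2 to compound 4 (within the scatter).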

Compound 4, largest response reached (Emax), in percent of the reference or control that the assay uses: 7.5%
The estimate for compound 4 lay 1.5 percentage points above the measured number, and the stated range covers the measured number.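

In this assay this pair gives the first readable step, a number 3.1 percentage points lower from compound 2 to compound 4 (within the scatter), and it shows that inverting this one stereocentre at a saturated ring carbon changes the maximal response by no more than the usual scatter. The earlier compounds offered no comparison of this kind, and the only structural difference within this pair is the following: the fact that one of compounds 2 and 4 is drawn with a defined configuration and the other without, at the place where they differ 

Still open, going by these compounds, is whether the other stereocentres behave the same way. Also open, on these data alone, is whether an amide in place of the ester of compound 2 would alter the response.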